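The compounds below may be only part of what the source reports. "The series", "measured", "known", "first", "only" and "open" are said of these compounds alone.

Measured in an assay on isolated protein for inhibition of hexokinase-3 (Rattus norvegicus), with a stated time of 6 h, tested at 10 mM; a lower number here means less inhibition, a higher number more inhibition at the concentration tested (going by the name of the read-out):

Compound 1 `O=C(CI)NCCCCCCC(=O)NCCCCCCNc1ncnc2c1ncn2[C@@H]1O[C@H](COP(=O)(O)OP(=O)(O)OP(=O)(O)O)[C@@H](O)[C@H]1O` gives 0%.
Compound 2 `O=C(CI)NCCC(=O)NCCCCCCNc1ncnc2c1ncn2[C@@H]1O[C@H](COP(=O)(O)OP(=O)(O)OP(=O)(O)O)[C@@H](O)[C@H]1O` gives 0%.
Compound 3 `Nc1ncnc2c1nc(NCCCCCCNC(=O)CI)n2[C@@H]1O[C@H](COP(=O)(O)OP(=O)(O)OP(=O)(O)O)[C@@H](O)[C@H]1O` gives 0%.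

The change from compound 1 to compound 2 is ((iodomethyl)carbonyl)amino in place of 4-(((iodomethyl)carbonyl)amino)butyl on a saturated chain carbon, two bonds along the chain from a carbonyl carbon, and the step it made was no change at the digits printed from compound 1 to compound 2 (within the scatter). Compound 3 stands level with compound 1 and compound 2. The difference between the core of compound 1 and the core of compound 3 is not broken down here.

Compound 4 `Nc1ncnc2c1nc(NCCNC(=O)CI)n2[C@@H]1O[C@H](COP(=O)(O)OP(=O)(O)OP(=O)(O)O)[C@@H](O)[C@H]1O` differs from compound 3 by ((iodomethyl)carbonyl)amino in place of 4-(((iodomethyl)carbonyl)amino)butyl on a saturated chain carbon, two bonds along the chain from a nitrogen on an aromatic ring. This is the same kind of change as that from compound 1 to compound 2, but the place differs: there it sits two bonds along the chain from a carbonyl carbon, here two bonds along the chain from a nitrogen on an aromatic ring.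

For compound 4 the expected step is no change at the digits printed from compound 3 to compound 4 (within the scatter), because the earlier step of no change at the digits printed from compound 1 to compound 2 (within the scatter) showed no change and all three measured compounds sit at the same level. Compound 4 is therefore estimated at 0%, between 0% and 10%.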

Compound 4, a percentage reported as inhibition, at one concentration (the size of the read-out at that concentration, not a potency): 0%
Beside the measured number, compound 4's estimate shows no gap at the digits printed, within the range that was stated.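

In this assay, ((iodomethyl)carbonyl)amino in place of 4-(((iodomethyl)carbonyl)amino)butyl gives no change at the digits printed from compound 3 to compound 4 (within the scatter), and this step matches the one seen earlier on the other core: the same change on two cores in this assay, no change at the digits printed (within the scatter) from compound 1 to compound 2 and no change at the digits printed (within the scatter) from compound 3 to compound 4, 0 percentage points apart, within the scatter of two such steps. The change therefore carries from one core to the other only in the narrow sense that it leaves the reading unmoved on both. This does not show how the change would act on a compound with measurable inhibition, as all four compounds read the same, with compound 4 at 0%.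

The compounds shown leave open whether a chloroacetyl amide or a free amine at the chain end would read differently in this assay. They also leave open whether a chain longer than 6-(((iodomethyl)carbonyl)amino)hexyl would do so.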